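A few compounds are considered here, and "the series" means these few. Any claim that something is new, unique, unknown or untested is made for them only; others in the source may bear on it.

In a functional assay on HL-60 cells (Homo sapiens) for antiproliferative activity, read by MTT assay, with a stated time of 24 h (on this read-out higher numbers stand for weaker inhibition and lower numbers for stronger inhibition), compound 1 `CCCCc1oc2ccccc2c1C(=O)c1ccc(OCC(=O)Nc2cccc(OC)c2)cc1` gives > 50000 nM, a limit of the assay and not a number. Compound 2 `CCCCNC(=O)CCCOc1ccc(C(=O)c2c(CCCC)oc3ccccc23)cc1` gives > 50000 nM, also only a limit. Compound 3 `CCCCc1oc2ccccc2c1C(=O)c1ccc(OCCCC(=O)N2CCCCC2)cc1` carries piperidin-1-yl in place of butylamino on a carbonyl carbon. The evidence so far is the limit of > 50000 nM in this assay, at which 2 of the 2 values shown sit. Going by the values given here, the only measured step is a step that the two limits leave unreadable from compound 1 to compound 2; it gives neither size nor direction, so no step beyond the scatter is expected in this assay. For compound 3 the estimated value is 50000 nM, with an expected range of 20000 nM to 100000 nM. The expected step is a number no higher from compound 2 to compound 3 (the limit leaves the size open).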

Compound 3, half-maximal inhibitory concentration: 31900 nM
The estimate for compound 3 lay 1.6-fold (0.20 log units) above the measured number, within the range that was stated.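

In this assay, going by these compounds alone, compound 3 is the first of the series to give a number and not a limit. Piperidin-1-yl in place of butylamino on a carbonyl carbon gives an at least 1.5-fold lower number from compound 2 to compound 3 (0.19 log units; that floor lies within the scatter), and 2-((piperidin-1-yl)carbonyl)ethyl in place of (3-methoxyphenyl)carbamoyl gives an at least 1.5-fold lower number from compound 1 to compound 3 (0.19 log units; that floor lies within the scatter). Neither step is therefore shown to lie beyond the scatter, and their true sizes stay open. Also open, on these data alone, is whether morpholin-4-yl, pyrrolidin-1-yl or a free carboxylic acid on the same carbonyl carbon would give a number clearly apart from that of compound 3.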